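Swapping the aryl group for an ester on the tetrazole carbon

A few compounds are considered here, and "the series" means these few. Any claim that something is new, unique, unknown or untested is made for them only; others in the source may bear on it.

Measured compounds:
compound 1 `CCCCCCCCc1ccc(OCC(=O)Cn2nnc(-c3ccc(Cl)cc3)n2)cc1`: 35 nM
compound 2 `CCCCCCCCc1ccc(OCC(=O)Cn2nnnc2-c2cccc(Cl)c2)cc1`: 360 nM

In an assay on microsomes from brain for inhibition of Fatty-acid amide hydrolase 1 (Rattus norvegicus), read by fluorescence and HPLC, with a stated time of 60 min (on this read-out lower numbers stand for stronger inhibition and higher numbers for weaker inhibition), compound 1 gives 35 nM. In this assay compound 2 gives 360 nM, the highest of the two numbers; compound 1 sits at a lower number, a gap beyond the scatter. The two compounds differ in more than one place, so the gap between them cannot be tied to a single change.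

Compound 3 `CCCCCCCCc1ccc(OCC(=O)Cn2nnnc2C(=O)OC)cc1` has not yet been measured. It is obtained from compound 2 by the change methoxycarbonyl in place of 3-chlorophenyl on an aromatic carbon: a methoxycarbonyl takes the place of the 3-chlorophenyl on an aromatic carbon of the five-membered aromatic ring with four nitrogens. Among the measured compounds shown here, no measured pair shows this change, so the size of its effect is uncertain. A step from compound 2 to compound 3 of a 2.5-fold higher number from compound 2 to compound 3 (0.40 log units; beyond the scatter) is expected, toward a higher number, beyond the scatter. Compound 3 is estimated at 900 nM, within 200 nM to 4000 nM.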

Compound 3, half-maximal inhibitory concentration: 1000 nM
Estimate against measurement, compound 3: 1.1-fold (0.05 log units) below; the measured number falls inside the stated range.
By their numbers in this assay, from the lowest: compound 1; then compound 2; then compound 3.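

Among the compounds shown here, this is the first pair differing in one place only, so a change on this carbon can now be sized. In this assay, methoxycarbonyl in place of 3-chlorophenyl on an aromatic carbon of the five-membered aromatic ring with 4 nitrogen gives a 2.8-fold higher number from compound 2 to compound 3 (0.44 log units; beyond the scatter), a modest loss that leaves compound 3 at 1000 nM, so inhibition weakens but survives with no ring on this carbon. Nothing measured here accounts for the step.

As far as these compounds go, this one pair cannot separate the loss of the 3-chlorophenyl from the arrival of the methoxycarbonyl, and how a carboxylic acid, an amide or a plain methyl would compare on this carbon remains open. Also open, from the compounds shown here alone, is whether the same swap would cost as much on the core of compound 1.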